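Chloro for Hydrogen on the Aryl Urea of Compound 2

The source may hold more compounds than are shown below. What is called first, only, known or untested is meant among the compounds shown, and "the series" means these compounds.

Of the compounds shown here, three sharing one core have been tested in a functional assay on HepG2 cells (Homo sapiens) for antiproliferative activity, read by MTT assay, with a stated time of 48 h; a higher number here means a weaker inhibitor, a lower number a stronger inhibitor. Compound 1 `O=C(Nc1cccc(CNc2nccnc2Cl)c1)Nc1cccc2ccccc12` gives only a limit of the assay, > 40000 nM (the limit of > 40000 nM in this assay, at which 1 of the 3 values shown sits). Compound 2 `O=C(Nc1ccccc1)Nc1cccc(CNc2nccnc2Cl)c1` gives 15600 nM in this assay, the higher of the two numbers that are numbers at all, while compound 3 `CCc1ccc(NC(=O)Nc2cccc(CNc3nccnc3Cl)c2)c(CC)c1` gives 10800 nM, a value that lies within the usual scatter of compound 2, so the two cannot be set in order.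

Compound 4 `O=C(Nc1ccc(Cl)cc1)Nc1cccc(CNc2nccnc2Cl)c1` is not yet measured. It differs from compound 2 in one place: chloro in place of hydrogen on an aromatic carbon. Within the data shown here, the change is the smallest possible, a single chlorine entering on an aromatic carbon of a six-membered aromatic ring of carbon only, and no measured pair shows what such an exchange does on this core. The step from compound 2 to compound 4 is therefore expected to be modest, most likely a small gain in potency or none beyond the scatter, as a 1.7-fold lower number from compound 2 to compound 4 (0.24 log units; within the scatter) expresses. Compound 4 is estimated to give 9000 nM in this assay, within a range from 3000 nM to 30000 nM.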

Compound 4, half-maximal inhibitory concentration: 8350 nM
Compound 4: the middle estimate sits 1.1-fold (0.03 log units) above what was measured; the range from low to high includes it.
By their numbers in this assay, from the lowest: compounds 4, 3 and 2 (each within the scatter of the next). At a limit, above all of these: compound 1.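

Among these compounds, the exchange of phenyl to 4-chlorophenyl gives the first readable step between two measured compounds on the shared core: in this assay, it is a 1.9-fold lower number from compound 2 to compound 4 (0.27 log units; within the scatter) for a single chlorine entering on an aromatic carbon, para to a large group. Compound 2 and compound 4 therefore stay within the scatter of each other, and this one exchange cannot set them in order. Nothing among the data shown bears on the reason for this result.

Going by these compounds, it remains open whether another group at this place, such as methoxy, an amine or a carboxylic acid, would give a step beyond the scatter. Also open, on these data alone, is whether the same chloro exchange would give a similar step on any other aromatic carbon of this ring.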